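Methyl in Place of Fluoro: Working Notes

The source may report more compounds than this note shows. Statements on the series, on what has been measured and on what is new or still open speak of the compounds shown alone.

Of the compounds shown here, two have been measured so far in a functional assay on CCRF-CEM cells (Homo sapiens) for inhibition; a lower number here means a stronger inhibitor, a higher number a weaker inhibitor. Compound 1 (`Cc1ccc(/C=C2\Cc3ccccc3C2=O)cc1`) gives 67100 nM, and compound 2 (`O=C1/C(=C/c2cccc(F)c2)CCc2ccccc21`) gives 8010 nM. Compound 2 therefore holds the lower of the two numbers, and the gap between them lies beyond the scatter. Among the measured compounds shown here, with only two values, this places compound 2 as the stronger inhibitor of this small set and shows no trend.

The next compound is compound 3 (`Cc1cccc(/C=C2\CCc3ccccc3C2=O)c1`), which keeps the core of compound 2. The change is methyl in place of fluoro on an aromatic carbon. For the measured compounds named here, the two measured compounds do not form a pair differing in one place, so no measured step shows how much such a swap matters in this assay. With no such evidence, no shift beyond the scatter is expected in either direction, and the value of compound 2, 8010 nM, serves as the anchor. The expected change is a 1.2-fold higher number from compound 2 to compound 3 (0.10 log units; within the scatter). For compound 3, the estimated value is 10000 nM, with an expected range from 3500 nM to 30000 nM.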

Compound 3, half-maximal inhibitory concentration: 9410 nM
For compound 3 the middle estimate is 1.1-fold (0.03 log units) above the measured one; the measured number falls inside the stated range.
By their numbers in this assay, from the lowest: compounds 2 and 3 (each within the scatter of the next); then compound 1.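

Methyl in place of fluoro on an aromatic carbon, meta to a large group, gives a 1.2-fold higher number from compound 2 to compound 3 (0.07 log units; within the scatter) in this assay and is the only step shown here between compounds that differ in one place. At this position on the shared core, the read-out therefore does not separate fluoro from methyl, something the pairing of compound 1 with compound 2 could not show, as those two differ in more than one place. No independent measurement bears on this result, so the step stands as an observation without an explanation.

Still open, from the compounds shown here alone, is whether a group of a different kind at this same carbon, such as an amine, a carboxylic acid or a longer chain, would give a step beyond the scatter, or whether the number stays as flat as it does for fluoro and methyl. Also open, going by these compounds, is whether methyl in place of fluoro would give a similarly small step on the other carbons of this ring or on the core of compound 1.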